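A few compounds are considered here, and "the series" means these few. Any claim that something is new, unique, unknown or untested is made for them only; others in the source may bear on it.

Of the compounds shown here, three have been measured in a functional assay on LM7 cells (Homo sapiens) for cytotoxicity, read by MTT assay, with a stated time of 72 h (a lower number here means a stronger inhibitor, a higher number a weaker inhibitor), and each of them returns only a limit of the assay rather than a number.

Compound 1 `O=c1cc(CSc2nc3ccccc3s2)oc2ccccc12`: in this assay compound 1 gives > 25000 nM, a limit.
Compound 2 `Cc1cc(C)nc(SCc2cc(=O)c3cc(Cl)ccc3o2)n1`: in this assay compound 2 gives > 25000 nM, a limit.
Compound 3 `O=c1cc(CSc2nc3ccccc3s2)oc2ccc(Cl)cc12`: in this assay compound 3 gives > 25000 nM, a limit.

Compound 3 and compound 1 differ in a single place, (hydrogen in place of chloro on an aromatic carbon). The size of this step, a step that the two limits leave unreadable from compound 3 to compound 1, cannot be read because of the limit of > 25000 nM in this assay, at which 3 of the 3 values shown sit. Compound 2 carries a different core from compound 3; the difference between the two cores is not broken down here.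

Compound 4 `Cc1cc(C)nc(SCc2cc(=O)c3ccccc3o2)n1` has not yet been measured. It stands to compound 2 exactly as compound 1 stands to compound 3: the change is hydrogen in place of chloro on an aromatic carbon, the same change at the same place on the ring. Within the data shown here, the one measured example of this change gave nothing readable, so there is no evidence that removing the chloro moves the result in either direction. The expectation for compound 4 therefore rests on compound 2, whose own result > 25000 nM is a limit. Compound 4 is expected to land at about 30000 nM, with a plausible span from 12000 nM to 100000 nM, and most probably as another limit rather than a number. The estimated step that the limit leaves unreadable from compound 2 to compound 4 is thus expected to be essentially none.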

Compound 4, half-maximal inhibitory concentration: > 25000 nM
Compound 4 ended at the assay's limit (the forecaster's own chance of this, stated with the estimate: 85%); the middle value lies beyond the limit too.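

The step from compound 2 to compound 4, hydrogen in place of chloro on an aromatic carbon, cannot be read, because both results are limits rather than numbers: the limit of > 25000 nM in this assay, at which 4 of the 4 values shown sit.

The compounds shown leave open what real number any of them would give in this assay, and so whether swapping the chloro for hydrogen changes the result at all.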